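Limits only so far in the chloro series

A few compounds are considered here, and "the series" means these few. Any claim that something is new, unique, unknown or untested is made for them only; others in the source may bear on it.

Measured in an ADME assay on Vero cells (Chlorocebus sabaeus) for cytotoxicity, read by neutral red uptake, with a stated time of 48 h; on this read-out lower numbers stand for stronger inhibition and higher numbers for weaker inhibition:
- compound 1 `Clc1ccc2c(NCCn3cnc4c(N5CCCC5)nc(Cl)nc43)ccnc2c1` gives > 11100 nM (a limit)
- compound 2 `CCN(CC)c1nc(Cl)nc2c1ncn2CCCNc1ccnc2cc(Cl)ccc12` gives > 10700 nM (a limit)
- compound 3 `Clc1ccc2c(NCCCn3cnc4c(N5CCCCC5)nc(Cl)nc43)ccnc2c1` gives > 10400 nM (a limit)

Compound 3 stands at > 10400 nM in this assay, which is a limit and not a number. The other two values shown are limits as well, so the series has no measured number yet.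

The next compound is compound 4 `CCN1CCN(c2nc(Cl)nc3c2ncn3CCCNc2ccnc3cc(Cl)ccc23)CC1`. The change is 4-ethylpiperazin-1-yl in place of piperidin-1-yl on an aromatic carbon.

Going by the values given here, the one measured step at this place is a step that the two limits leave unreadable from compound 2 to compound 3 and it gives no size to carry over. No step beyond the scatter is therefore expected in this assay, though the data give no firm support for this and fix no direction. The expected change is an at least 1.0-fold lower number from compound 3 to compound 4 (0.01 log units; that floor lies within the scatter) and it may again be hidden behind a limit. For compound 4 the estimated value is 10000 nM in this assay, with an expected range from 3500 nM to 20000 nM in that assay.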

Compound 4, half-maximal inhibitory concentration: > 9830 nM
Compound 4 ended at the assay's limit; the forecaster's own chance of this, stated with the estimate: 75%; the middle value does not contradict the limit.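

In this assay compound 4 gives > 9830 nM, a limit and not a number, so no step can be read from compound 2 or compound 3 to compound 4. The compounds shown leave open whether swapping these amine groups shifts cytotoxicity at all, since all four values remain limits.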